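Swapping oxan-2-yl for oxolan-2-yl in compound 2

The source may report more compounds than this note shows. Statements on the series, on what has been measured and on what is new or still open speak of the compounds shown alone.

Of the compounds shown here, three sharing one core have been measured in an ADME assay on K562 cells (Homo sapiens) for cytotoxicity, with a stated time of 72 h; a lower number here means a stronger inhibitor, a higher number a weaker inhibitor. Compound 1 `COc1cccc(CNc2ncnc3c2ncn3C2CCCCO2)c1` gives 61000 nM. Compound 2 `COc1ccc(OC)c(CNc2ncnc3c2ncn3C2CCCCO2)c1` gives 16500 nM, the lowest number in the set, and adding a methoxy group brings a 3.7-fold lower number from compound 1 to compound 2 (0.57 log units; beyond the scatter). Compound 3 `COc1cc(OC)c(OC)cc1CNc1ncnc2c1ncn2C1CCCCO1` is reported only as a limit of the assay, > 100000 nM. One more methoxy group gives an at least 6.0-fold higher number from compound 2 to compound 3 (0.78 log units; beyond the scatter), so the two additions of this group do not pull in the same direction.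

Compound 4 `COc1ccc(OC)c(CNc2ncnc3c2ncn3C2CCCO2)c1` differs from compound 2 in one place only: oxolan-2-yl in place of oxan-2-yl on an aromatic nitrogen. In words, oxolan-2-yl stands in place of oxan-2-yl on an aromatic nitrogen. All three measured compounds carry oxan-2-yl, and both measured steps put methoxy in place of hydrogen on an aromatic carbon, so neither speaks directly to this change. They serve only as a gauge of size. With a 3.7-fold lower number from compound 1 to compound 2 (0.57 log units; beyond the scatter) as a guide to what one small change can do, no clear step is expected in this assay, though a modest move in either direction would not surprise. The expected change is a 1.2-fold higher number from compound 2 to compound 4 (0.08 log units; within the scatter). Compound 4 is estimated at 20000 nM, with an expected range of 7000 nM to 60000 nM.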

Compound 4, half-maximal inhibitory concentration: > 50000 nM
Compound 4 was reported as a limit (the forecaster's own chance of this, stated with the estimate: 10%); middle value at least 2.5-fold (0.39 log units) from the limit.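

Within the data shown here, the position on the aromatic nitrogen, which the earlier compounds left unvaried, is not silent: in this assay the five-membered oxolan-2-yl in place of the six-membered oxan-2-yl gives an at least 3.0-fold higher number from compound 2 to compound 4 (0.48 log units; beyond the scatter) and is the first change there with a readable effect. Compound 4 stands at > 50000 nM, which is a limit of the assay and not a number, so the step has a floor but no fixed size: the limit of > 50000 nM in this assay, at which 1 of the 4 values shown sits. Until now only changes on an aromatic carbon had shown movement, and the second methoxy addition (an at least 6.0-fold higher number from compound 2 to compound 3 (0.78 log units; beyond the scatter)) also took compound 2 to a higher number, so compound 2 has now risen with a single change at either of two places.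

The compounds shown leave open how the number responds to other groups on this nitrogen, such as an open butyl chain, a cyclopentyl ring without the ring oxygen, or a ring carrying an amine. They also leave open whether oxolan-2-yl would give a step of the same direction alongside the methoxy pattern of compound 1 or compound 3.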